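The source may hold more compounds than are shown below. What is called first, only, known or untested is meant among the compounds shown, and "the series" means these compounds.

Within the data shown here, compound 2, built as `CCCc1cc(C(C)=O)c(O)cc1OCCCCCC(C)(C)c1nnn[nH]1`, is one of two compounds measured in an assay on isolated protein for antagonist activity at Bile acid receptor (Homo sapiens), read by HTRF, with a stated time of 30 min (on this read-out higher numbers stand for weaker inhibition and lower numbers for stronger inhibition), where compound 2 gives 25200 nM. Among the measured compounds shown here, its only companion is compound 1, built as `CCCCc1cc(CC)c(O)cc1OCCCCCC(C)(C)c1nnn[nH]1`, which in this assay gives 8700 nM, a lower number that lies beyond the scatter; compound 1 and compound 2 differ in two places, so no single step between them is defined. Compound 3, built as `CCCCc1cc(C(C)=O)c(O)cc1OCCCCCC(C)(C)c1nnn[nH]1`, is not yet measured. It differs from compound 2 by methyl in place of hydrogen on a saturated chain carbon, three bonds along the chain from an aromatic carbon. For the measured compounds named here, with no comparable step at hand, the expected step of a 1.6-fold lower number from compound 2 to compound 3 (0.20 log units; within the scatter) is small, likely within the scatter, leaning towards a lower number. For compound 3 the estimate in this assay is 16000 nM, with a range from 6000 nM to 40000 nM.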

Compound 3, half-maximal inhibitory concentration: 1500 nM
The estimate for compound 3 lay 11-fold (1.03 log units) above the measured number; the measured number lies below the stated range.
By their numbers in this assay, from the lowest: compound 3; then compound 1; then compound 2.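

Extending propyl to butyl at this chain position gives a 17-fold lower number from compound 2 to compound 3 (1.23 log units; beyond the scatter) in this assay and shows that this single added methyl can shift the number strongly, which the earlier pair, differing in two places, could not show. With butyl held in place, acetyl in place of ethyl on an aromatic carbon gives a 5.8-fold lower number from compound 1 to compound 3 (0.76 log units; beyond the scatter) on the same read-out. Nothing at hand gives a reason for either step. On these data alone, whether a pentyl chain would lower the number further remains open, as does how an amide or a carboxylic acid would compare with the acetyl.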